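Lipophilicity Estimate for Compound 4 from Three Measured Analogues

The source may hold more compounds than are shown below. What is called first, only, known or untested is meant among the compounds shown, and "the series" means these compounds.

Measured compounds:
compound 1, `Cc1cc(C)c(-c2cn(C)cn2)cc1NC(=O)c1ccc(OCc2ccccn2)cc1`: 3
compound 2, `Cc1csc(-c2cc(NC(=O)c3ccc(OCc4ccccn4)cc3)c(C)cc2C)n1`: > 3
compound 3, `Cc1cc(C)c(-c2c(C)nn(C)c2C)cc1NC(=O)c1ccc(OCc2ccccn2)cc1`: > 3

In a physicochemical assay for lipophilicity (on this read-out lower numbers stand for lower lipophilicity and higher numbers for higher lipophilicity), compound 1 gives 3. For compound 2 the result > 3 is a limit of the assay, not a number. For compound 3 the result > 3 is likewise a limit. This is the limit of > 3 in this assay, at which 2 of the 3 values shown sit. Accordingly the steps of a number no lower from compound 1 to compound 2 (the limit leaves the size open) and a number no lower from compound 1 to compound 3 (the limit leaves the size open) are bounded on one side only, and the step that the two limits leave unreadable from compound 2 to compound 3 cannot be read at all. Compound 3 therefore stands at the limit, with no number of its own.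

Compound 4, `Cc1cc(C)c(-c2ccc(N)nn2)cc1NC(=O)c1ccc(OCc2ccccn2)cc1`, is not yet measured. It differs from compound 3 by 6-aminopyridazin-3-yl in place of 1,3,5-trimethyl-1H-pyrazol-4-yl on an aromatic carbon. Going by the values given here, none of the measured steps involves a change of this kind, and the two steps ending at compound 3 have no readable size, so they give no measure of what to expect. The change is expected to move compound 4 downward in this assay, as the step of a number at least 0.60 log units lower from compound 3 to compound 4 (beyond the scatter) estimated here. Compound 4 is estimated at 2.4, with a range from 1.7 to 3.1.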

Compound 4, distribution coefficient: 2.6
Beside the measured number, compound 4's estimate is 0.20 log units below it; measured number inside the range.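

In this assay, going by these compounds alone, 6-aminopyridazin-3-yl on this aromatic carbon, ortho to a methyl group, gives the first step with a readable size, as 1-methyl-1H-imidazol-4-yl gives way to it: a number 0.40 log units lower from compound 1 to compound 4 (beyond the scatter). Set against the two groups whose compounds stand at a limit, the same change gives a number at least 0.40 log units lower from compound 3 to compound 4 (beyond the scatter) and a number at least 0.40 log units lower from compound 2 to compound 4 (beyond the scatter), sizes that are bounded on one side only. This place on the shared core thus shows a change beyond the scatter, while only compound 1 and compound 4 carry numbers and the others rest at a limit: the limit of > 3 in this assay, at which 2 of the 4 values shown sit.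

As far as these compounds go, whether a pyridazin-3-yl group without the amine, or a dimethylamino group on the same ring, would read like compound 4 stays open. From the compounds shown here alone, how far compound 2 and compound 3 truly lie from compound 4 also stays open, and the step between compound 2 and compound 3 cannot be read.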